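A few compounds are considered here, and "the series" means these few. Any claim that something is new, unique, unknown or untested is made for them only; others in the source may bear on it.

Measured in an ADME assay on TZM cells (Homo sapiens) for cytotoxicity, read by XTT assay, with a stated time of 4 days (a lower number here means that less compound is tolerated, a higher number that more compound is tolerated), all three entries being limits:
- Compound 1 `Cc1cc(/C=C/C#N)cc(C)c1Oc1cc(Nc2ccc(C#N)cc2)c(N)cc1[N+](=O)[O-]`: > 24400 nM
- Compound 2 `Cc1cc(/C=C/C#N)cc(C)c1Oc1cc(Nc2ccc(C#N)cc2)c(N)cc1S(N)(=O)=O`: > 21800 nM
- Compound 3 `CNC(=O)c1cc(N)c(Nc2ccc(C#N)cc2)cc1Oc1c(C)cc(/C=C/C#N)cc1C`: > 9200 nM

Compound 2 stands only at a limit, > 21800 nM, and has no exact number. Compound 4 `Cc1cc(CCC#N)cc(C)c1Oc1cc(Nc2ccc(C#N)cc2)c(N)cc1S(N)(=O)=O` carries 2-cyanoethyl in place of 2-cyanoethenyl on an aromatic carbon. Going by the values given here, no measured step alters that group, and none has a readable size: a step that the two limits leave unreadable from compound 1 to compound 2, a step that the two limits leave unreadable from compound 1 to compound 3 and a step that the two limits leave unreadable from compound 2 to compound 3. They bear on it only indirectly. Compound 2 gives the sole anchor with its limit of > 21800 nM, so no step beyond the scatter is expected in this assay. The expected step is an at least 1.0-fold lower number from compound 2 to compound 4 (0.03 log units; that floor lies within the scatter). Compound 4 is estimated at 20000 nM, within an expected range of 8000 nM to 30000 nM.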

Compound 4, half-maximal cytotoxic concentration: 11100 nM
Compound 4: the middle estimate sits 1.8-fold (0.26 log units) above what was measured; measured number inside the range.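

In this assay, compound 4 is the first of these compounds with an exact number, and its 2-cyanoethyl is the first change at this position, whereas the steps among compound 1, compound 2 and compound 3 cannot be read. The change gives an at least 1.9-fold lower number from compound 2 to compound 4 (0.29 log units; that floor lies within the scatter), so it is not shown to move the number beyond the usual scatter. That step is only a floor because compound 2 stands at a limit: the limit of > 21800 nM in this assay, at which 1 of the 4 values shown sits.

On these data alone, how an amine or a longer chain at this position would read stays open. So does whether 2-cyanoethyl acts alike with nitro or methylcarbamoyl in place of sulfamoyl.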